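Swapping Diethylamino for Dipropylamino on the Chain

This account rests on a few compounds, and the source may have more. Where it says the series, first, only, none or still open, it means among the compounds named here.

Compound 1 `CCCCCCCOc1c(-c2cc(OC)c(OC)c(OC)c2)oc2ccccc2c1=O`: > 50000 nM, a limit
Compound 2 `CCN(CC)CCCOc1c(-c2cc(OC)c(OC)c(OC)c2)oc2ccccc2c1=O`: 13600 nM
Compound 3 `CCN(CC)CCCCCOc1c(-c2cc(OC)c(OC)c(OC)c2)oc2ccccc2c1=O`: 6600 nM

In a functional assay on PC-3 cells (Homo sapiens) for antiproliferative activity, read by WST assay, with a stated time of 3 days (a lower number here means a stronger inhibitor, a higher number a weaker inhibitor), compound 3 gives the lowest number, 6600 nM. Compound 4 `CCCN(CCC)CCCCCOc1c(-c2cc(OC)c(OC)c(OC)c2)oc2ccccc2c1=O` differs from it only at the chain end: dipropylamino in place of diethylamino on a saturated chain carbon, five bonds along the chain from an oxygen on an aromatic ring. Among the measured compounds shown here, no measured step makes this exact change. The nearest is a 2.1-fold lower number from compound 2 to compound 3 (0.31 log units; beyond the scatter), with 2-(diethylamino)ethyl in place of diethylamino. The step of an at least 7.5-fold lower number from compound 1 to compound 3 (0.87 log units; beyond the scatter) is larger, but it puts in the diethylamino group, and compound 4 keeps an amino group there. Only a small move towards a lower number is therefore expected, probably within the scatter. The expected step is a 1.3-fold lower number from compound 3 to compound 4 (0.12 log units; within the scatter). Compound 4 is estimated at 5000 nM, within a range of 2000 nM to 13000 nM.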

Compound 4, half-maximal inhibitory concentration: 2600 nM
Beside the measured number, compound 4's estimate is 1.9-fold (0.28 log units) above it; measured number inside the range.
By their numbers in this assay, from the lowest: compound 4; then compound 3; then compound 2. At a limit, above all of these: compound 1.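

Earlier steps had altered only the chain carrying the amine, and here the groups on the nitrogen alone prove to matter in this assay, with dipropylamino in place of diethylamino giving a 2.5-fold lower number from compound 3 to compound 4 (0.40 log units; beyond the scatter). Combined with the longer chain, the change gives a 5.2-fold lower number from compound 2 to compound 4 (0.72 log units; beyond the scatter). Compound 1 carries only a limit, so the largest step, an at least 19-fold lower number from compound 1 to compound 4 (1.28 log units; beyond the scatter), is a bound: the limit of > 50000 nM in this assay, at which 1 of the 4 values shown sits.

The compounds shown leave open whether dibutylamino or a ring amine such as piperidine would lower the number further. They also leave open whether a longer chain would do so with dipropylamino in place.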